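Working notes: from compound 2 to compound 3

The source may report more compounds than this note shows. Statements on the series, on what has been measured and on what is new or still open speak of the compounds shown alone.

Measured in a functional assay on A-375 cells (Homo sapiens) for antiproliferative activity, read by CCK-8 assay, with a stated time of 72 h; on this read-out lower numbers stand for stronger inhibition and higher numbers for weaker inhibition:
- compound 1 `Nc1ccccc1NC(=O)c1ccc(Cn2cnc3c(Nc4ccccc4)nc(Cl)nc32)cc1` gives 2800 nM
- compound 2 `Nc1ccccc1NC(=O)c1ccc(Cn2cnc3c(Nc4cccc(Cl)c4)nc(Cl)nc32)cc1` gives 6080 nM

Of the two numbers, compound 2 has the higher one, so it is the weaker of the pair in this assay. The next compound, compound 3 `CN1CCN(c2nc(Cl)nc3c2ncn3Cc2ccc(C(=O)Nc3ccccc3N)cc2)CC1`, carries this change from compound 2: 4-methylpiperazin-1-yl in place of (3-chlorophenyl)amino on an aromatic carbon. Within the data shown here, only one measured step bears on it, and only indirectly: a 2.2-fold higher number from compound 1 to compound 2 (0.34 log units; beyond the scatter) is modest and comes from chloro in place of hydrogen on an aromatic carbon. Among the measured compounds shown here, no measured compound shows a replacement of the whole (3-chlorophenyl)amino group, so the direction of the new step remains poorly defined. A step of modest size is expected, leaning towards a lower number, as compound 1 at 2800 nM lies lower without the chloro. The expected step is a 1.5-fold lower number from compound 2 to compound 3 (0.18 log units; within the scatter). For compound 3 the estimated value is 4000 nM, with an expected range from 1200 nM to 15000 nM.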

Compound 3, half-maximal inhibitory concentration: 1600 nM
Beside the measured number, compound 3's estimate is 2.5-fold (0.40 log units) above it; the measured number falls inside the stated range.
By their numbers in this assay, from the lowest: compounds 3 and 1 (each within the scatter of the next); then compound 2.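

In this assay, 4-methylpiperazin-1-yl in place of (3-chlorophenyl)amino gives a 3.8-fold lower number from compound 2 to compound 3 (0.58 log units; beyond the scatter), so at this position neither an aromatic ring nor a hydrogen-bond donor on the substituent is required for a number in this range. Set against the plain anilino group, the same ring gives a 1.8-fold lower number from compound 1 to compound 3 (0.24 log units; within the scatter), which lies within the scatter, so the two groups cannot be told apart here and the benefit is seen only relative to the (3-chlorophenyl)amino group. No independent data are available to explain the difference between these substituents.

The compounds shown leave open whether the methyl on the piperazine ring contributes, as piperazine with a free ring nitrogen would test. They also leave open whether morpholine or an open-chain dimethylamino group would give similar numbers at this position.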